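The source may hold more compounds than are shown below. What is called first, only, known or untested is meant among the compounds shown, and "the series" means these compounds.

Measured compounds, with their readings in a functional assay on CHO cells with adenosine receptor A1 (Homo sapiens) as the target, read by cAMP accumulation and immunoassay, with a stated time of 6 min, tested at 10 uM; a lower number here means a stronger effect, a higher number a weaker effect of the compound at the concentration tested:
- compound 1, `Nc1scc(CN2CCN(c3cc(Cl)cc(Cl)c3)CC2)c1C(=O)c1ccc(Cl)cc1`: -74%
- compound 2, `Nc1scc(CN2CCN(c3ccc([N+](=O)[O-])cc3)CC2)c1C(=O)c1ccc(Cl)cc1`: -17%
- compound 3, `Nc1scc(CN2CCN(c3ccc(OC(F)(F)F)cc3)CC2)c1C(=O)c1ccc(Cl)cc1`: -74%

Compound 3 stands level with compound 1; the two together give the lowest numbers of the three, and compound 2 sits well apart, a number 57 percentage points lower from compound 2 to compound 3 (beyond the scatter). The swap on the ring nitrogen between compound 1 and compound 3 gives no change at the digits printed from compound 1 to compound 3 (within the scatter), so a 3,5-dichlorophenyl and a 4-(trifluoromethoxy)phenyl read alike, whereas the 4-nitrophenyl of compound 2 reads far weaker, a number 57 percentage points higher from compound 1 to compound 2 (beyond the scatter).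

Compound 4, `Nc1scc(CN2CCN(c3cc(F)cc(F)c3)CC2)c1C(=O)c1ccc(Cl)cc1`, carries the change (3,5-difluorophenyl in place of 4-(trifluoromethoxy)phenyl on an amine nitrogen in a ring). Its group matches the substitution pattern of compound 1 rather than that of compound 2, and the only large shift seen so far came with the nitro group of compound 2. The step that bears most directly is no change at the digits printed from compound 1 to compound 3 (within the scatter), which was flat. Compound 4 is therefore expected to show a number 4 percentage points higher from compound 3 to compound 4 (within the scatter), a step of no size beyond the scatter, and an estimated reading of -70%, within -88% to -45%.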

Compound 4, a percentage reported as activity, at one concentration (the size of the read-out at that concentration, not a potency): -79%
For compound 4 the middle estimate is 9 percentage points above the measured one, within the range that was stated.
By their numbers in this assay, from the lowest: compounds 4, 1 and 3 (each within the scatter of the next); then compound 2.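

In this assay, 3,5-difluorophenyl on the amine nitrogen in a ring reads alike with both earlier groups, with a number 5 percentage points lower from compound 3 to compound 4 (within the scatter) for the exchange of 4-(trifluoromethoxy)phenyl and a number 5 percentage points lower from compound 1 to compound 4 (within the scatter) for the exchange of 3,5-dichlorophenyl. Among the four compounds, the large shift stays with the 4-nitrophenyl of compound 2 alone, and the new comparison gives a number 62 percentage points lower from compound 2 to compound 4 (beyond the scatter) for the exchange of that group. No measured evidence is available to explain why three of these aryl groups read alike or why compound 2 departs from them.

Open, going by these compounds, is whether the reading at this position survives replacing the phenyl ring with a cyclohexyl group or a short alkyl chain. Also open, on these data alone, is how a phenyl ring bearing an amine or a carboxylic acid would read.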